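The compounds below may be only part of what the source reports. "The series", "measured", "known", "first", "only" and "open" are said of these compounds alone.

Series notes, cytotoxicity on the shared core.

Three compounds of the series have been run in a functional assay on A549 cells (Homo sapiens) for cytotoxicity, read by MTT assay; on this read-out higher numbers stand for weaker inhibition and lower numbers for stronger inhibition. Compound 1 `CCOC(=O)c1oc2cc(OC)cc(OC)c2c1C` carries no carbamoyl on the core; in this assay compound 1 gives "not active" (no number reported). Compound 2 `CCOC(=O)c1oc2c(C(N)=O)c(OC)cc(OC)c2c1C` adds a carbamoyl to the benzene part of the core while keeping the ethyl ester; in this assay compound 2 gives "not active" (no number reported). Compound 3 `COc1cc(OC)c2c(C)c(C(N)=O)oc2c1C(N)=O` carries two carbamoyl groups and no ester; in this assay compound 3 gives 39400 nM. Going by the values given here, compound 3 is therefore the only member of the series with a single number to its name; the other two entries stand without one, so no measured step can be drawn.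

Compound 4 `COc1cc(OC)c2c(C)c(C=O)oc2c1C(N)=O` differs from compound 3 in one place: hydrogen in place of amino on a carbonyl carbon. The change is small in atom count and touches one of the two carbonyl groups only. Among the compounds with values here, with no measured step available for this kind of exchange, and with the whole series lying at the weak end of this assay, the expectation is a step of a 1.0-fold higher number from compound 3 to compound 4 (0.01 log units; within the scatter), which is not beyond the usual scatter and has no preferred direction. Compound 4 is accordingly estimated at 40000 nM in this assay, with a plausible range from 15000 nM to 120000 nM, and a real chance that only an inactive result is reported, as for compound 1 and compound 2.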

Compound 4, half-maximal inhibitory concentration: 63800 nM
Compound 4: middle estimate off by 1.6-fold (0.20 log units), on the low side, and the stated range covers the measured number.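

In this assay, going by these compounds alone, carbamoyl to formyl on this carbonyl carbon gives a 1.6-fold higher number from compound 3 to compound 4 (0.21 log units; within the scatter), the first measured step, and the only one that can be read, since compound 1 and compound 2 have no number to form a step. It shows that the amino group on this carbonyl carbon is not needed for a number to be obtained: with hydrogen in its place, compound 4 gives 63800 nM, while compound 2, with the ethyl ester on the same ring carbon, gives "not active" (no number reported). Nothing measured on these compounds bears on why the exchange leaves the number within the scatter.

Still open, from the compounds shown here alone, is whether a carboxylic acid, an acetyl group or a methylamide on this carbonyl carbon would also stay within the scatter of compound 3 or would move the number clearly in either direction. Equally open, going by these compounds, is what a primary amine or a hydroxymethyl group at this place would give, and whether any such exchange would bring the series away from the weak end of this assay.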